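The source may hold more compounds than are shown below. What is called first, only, known or untested is meant among the compounds shown, and "the series" means these compounds.

Measured compounds:
- compound 1, `NS(=O)(=O)c1cc(-c2nnc(CN3CCC(Cc4ccccc4)CC3)o2)c(Cl)cc1SCc1ccccc1`, gives 19000 nM
- compound 2, `Cc1ccc(C)c(N2CCN(Cc3nnc(-c4cc(S(N)(=O)=O)c(SCc5ccccc5)cc4Cl)o3)CC2)c1`, gives 17000 nM
- compound 3, `NC(=O)c1cn(Cc2nnc(-c3cc(S(N)(=O)=O)c(SCc4ccccc4)cc3Cl)o2)nn1`, gives 72000 nM

All three were tested in a functional assay on HCT-116 cells (Homo sapiens) for cytotoxicity, read by MTT assay, with a stated time of 72 h; on this read-out higher numbers stand for weaker inhibition and lower numbers for stronger inhibition. Compound 3 stands at the highest number of the three; its gap to compound 1 and its gap to compound 2 both lie beyond the usual scatter, so compound 3 is the weakest of the three in this assay. Compound 1 and compound 2 differ from each other by an amount that sits within the scatter, so no order between those two can be read from the numbers.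

Compound 4, `NS(=O)(=O)c1cc(-c2nnc(/C=C/c3cccc(Cl)c3)o2)c(Cl)cc1SCc1ccccc1`, has not yet been measured. It differs from compound 3 in one place: 2-(3-chlorophenyl)ethenyl in place of (4-carbamoyl-1H-1,2,3-triazol-1-yl)methyl on an aromatic carbon. Within the data shown here, no pair of measured compounds differing in only one place is available, so the size of this step cannot be taken from a known comparison. Compound 1 and compound 2 carry other groups at the same place on the shared core and give lower numbers than compound 3, which suggests that changing this group can move the number downward. The expected step of a 2.9-fold lower number from compound 3 to compound 4 (0.46 log units; beyond the scatter) is therefore a moderate fall. Compound 4 is estimated at 25000 nM, with a range from 8000 nM to 80000 nM.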

Compound 4, half-maximal inhibitory concentration: 12000 nM
Beside the measured number, compound 4's estimate is 2.1-fold (0.32 log units) above it; the measured number falls inside the stated range.
By their numbers in this assay, from the lowest: compounds 4, 2 and 1 (each within the scatter of the next); then compound 3.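

In this assay, among these compounds, replacing (4-carbamoyl-1H-1,2,3-triazol-1-yl)methyl with 2-(3-chlorophenyl)ethenyl on this aromatic carbon gives a 6.0-fold lower number from compound 3 to compound 4 (0.78 log units; beyond the scatter), the only step that can be read at this position, and the two groups have the same number of heavy atoms. The swap changes several things at once: the five-membered aromatic ring with 3 hetero atoms gives way to a six-membered aromatic ring of carbon only, and the entering group has no hydrogen-bond donors or acceptors, so this single step cannot show which feature goes with the lower number. Compound 4 at 12000 nM lies within the scatter of compound 2 at 17000 nM, so no order can be drawn between them, and nothing measured here offers a reason for the step.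

The compounds shown leave open how much of the step belongs to the chlorine and how much to the ethenyl link, as a plain 2-phenylethenyl group or a 2-phenylethyl chain at this place could tell. They also leave open what a carboxylic acid at this place would do.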